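The source may hold more compounds than are shown below. What is called first, only, known or untested is meant among the compounds shown, and "the series" means these compounds.

The measured compounds in a functional assay on HeLa cells (Homo sapiens) for inhibition, read by MTT assay, with a stated time of 24 h; a lower number here means a stronger inhibitor, a higher number a weaker inhibitor:

compound 1, `CCOC(=O)C1=Cc2ccccc2OC1(OCc1cn(CC(=O)Nc2cccc(Cl)c2)nn1)C(F)(F)F`: 12300 nM
compound 2, `CCOC(=O)C1=Cc2ccccc2OC1(OCc1cc(-c2ccc(Br)cc2)no1)C(F)(F)F`: 52300 nM
compound 3, `O=C(O)C1=Cc2ccccc2OC1(OCc1cc(-c2ccc(F)cc2F)no1)C(F)(F)F`: > 150000 nM

Of the two numbers, compound 1 has the lowest; compound 2 gives a higher number in this assay, and that gap lies beyond the usual scatter. Compound 3 gives only a limit, (the limit of > 150000 nM in this assay, at which 1 of the 3 values shown sits), and no number. Compound 4, `CCOC(=O)C1=Cc2ccccc2OC1(OCc1cn(CC(=O)Nc2ccc(I)cc2Cl)nn1)C(F)(F)F`, is not yet measured. It differs from compound 1 in one place: 2-chloro-4-iodophenyl in place of 3-chlorophenyl on an amide-type nitrogen. Going by the values given here, no step between measured compounds bears on this change, so nothing here points in either direction, and the step of a 1.1-fold lower number from compound 1 to compound 4 (0.05 log units; within the scatter) is expected to stay within the scatter. Compound 4 is therefore expected to give about 11000 nM in this assay, within a range from 3500 nM to 40000 nM.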

Compound 4, half-maximal inhibitory concentration: 26100 nM
The estimate for compound 4 lay 2.4-fold (0.38 log units) below the measured number; the range from low to high includes it.
By their numbers in this assay, from the lowest: compound 1; then compounds 4 and 2 (each within the scatter of the next). At a limit, above all of these: compound 3.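

In this assay, 2-chloro-4-iodophenyl in place of 3-chlorophenyl on the amide-type nitrogen gives a 2.1-fold higher number from compound 1 to compound 4 (0.33 log units; beyond the scatter), a modest step. It is the first step shown at this position, and it shows that the number responds to the substitution of this phenyl ring. Nothing measured here accounts for the change.

From the compounds shown here alone, the chlorine's new place and the added iodine arrive together, so it stays open whether 2-chlorophenyl or 4-iodophenyl alone would produce this step. Going by these compounds, the outcome with an amine or a methoxy group on this ring also remains open.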